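From 2-fluorobenzyl to 4-fluorobenzyl: working notes

The compounds below may be only part of what the source reports. "The series", "measured", "known", "first", "only" and "open" are said of these compounds alone.

compound 1 `Fc1ccccc1CSc1nnc(-c2ccncc2)n1-c1ccccc1` gives > 50000 nM as a limit
compound 2 `Brc1ccccc1CSc1nnc(-c2ccncc2)n1-c1ccccc1` gives 17100 nM
compound 3 `Clc1cccc(CSc2nnc(-c3ccncc3)n2-c2ccccc2)c1` gives 11200 nM

All three were read in a functional assay on HepG2 cells (Homo sapiens) for inhibition, read by MTT assay, with a stated time of 48 h (a lower number here means a stronger inhibitor, a higher number a weaker inhibitor), and only compound 2 and compound 3 have numbers. Compound 1 has no number, only the limit of > 50000 nM in this assay, at which 1 of the 3 values shown sits, as its standing.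

The change to compound 4 `Fc1ccc(CSc2nnc(-c3ccncc3)n2-c2ccccc2)cc1` is 4-fluorophenyl in place of 2-fluorophenyl on a saturated chain carbon bound to a sulfur. The same atoms stay, joined differently.

Two measured steps leave the 2-fluorophenyl of compound 1. One is an at least 2.9-fold lower number from compound 1 to compound 2 (0.46 log units; beyond the scatter) with bromo in place of fluoro. The other is an at least 4.4-fold lower number from compound 1 to compound 3 (0.64 log units; beyond the scatter) with 3-chlorophenyl entering. The gap between their end points is small, at a 1.5-fold lower number from compound 2 to compound 3 (0.18 log units; within the scatter) and so within the scatter. Neither step keeps the fluoro group, so they bear on this change only indirectly. A modest step to a lower number is expected, and another limit remains possible.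

The expected change is an at least 1.6-fold lower number from compound 1 to compound 4 (0.22 log units; that floor lies within the scatter) in this assay.

For compound 4 the estimated value is 30000 nM with an expected range from 12000 nM to 70000 nM.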

Compound 4, half-maximal inhibitory concentration: 15600 nM
For compound 4 the middle estimate is 1.9-fold (0.28 log units) above the measured one; the range from low to high includes it.
By their numbers in this assay, from the lowest: compounds 3, 4 and 2 (each within the scatter of the next). At a limit, above all of these: compound 1.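

In this assay, moving the fluoro group with no other change is enough for a step beyond the scatter: an at least 3.2-fold lower number from compound 1 to compound 4 (0.50 log units; beyond the scatter). The earlier steps shown here from compound 1 all exchanged the halogen as well, whereas this one shows that the fluoro group does not by itself keep a compound at a limit, and compound 4 reads with the other two measured compounds: a 1.4-fold higher number from compound 3 to compound 4 (0.14 log units; within the scatter), and a 1.1-fold lower number from compound 2 to compound 4 (0.04 log units; within the scatter). Compound 1 still has no number, only a limit: the limit of > 50000 nM in this assay, at which 1 of the 4 values shown sits.

On these data alone, all four compounds carry a single halogen on the phenyl ring, so the effect of an amine or a carboxylic acid in its place remains open. Equally open, as far as these compounds go, is how a longer chain in place of the fluorobenzyl group would read in this assay.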